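The source may hold more compounds than are shown below. What is called first, only, known or untested is meant among the compounds shown, and "the series" means these compounds.

Working notes on the series. Within the data shown here, in a functional assay on MGC-803 cells (Homo sapiens) for antiproliferative activity, read by MTT assay, with a stated time of 72 h (on this read-out lower numbers stand for stronger inhibition and higher numbers for weaker inhibition), compound 2 `C/C(=N\Nc1nc(SCc2ccccc2)nc2c1nnn2Cc1ccccc1)c1ccccc1O` gives 850 nM, the lower of the two numbers measured so far; compound 1 `CCCSc1nc(N/N=C(\C)c2ccc(OC)cc2)c2nnn(Cc3ccccc3)c2n1` gives 44300 nM, a gap beyond the usual scatter, but these two compounds differ in more than one place, so no single change can be read from it. Compound 3 `CCCSc1nc(N/N=C(\C)c2ccccc2O)c2nnn(Cc3ccccc3)c2n1` carries ethyl in place of phenyl on a saturated chain carbon bound to a sulfur. Among the measured compounds shown here, with no single-change step to lean on, a modest loss is expected in this assay, a 3.5-fold higher number from compound 2 to compound 3 (0.55 log units; beyond the scatter). Compound 3 is therefore estimated at 3000 nM, within a range of 600 nM to 15000 nM.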

Compound 3, half-maximal inhibitory concentration: 2310 nM
Compound 3: middle estimate off by 1.3-fold (0.11 log units), on the high side; the range from low to high includes it.
By their numbers in this assay, from the lowest: compound 2; then compound 3; then compound 1.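

In this assay the group on sulfur can now be read on its own: ethyl in place of phenyl on a saturated chain carbon bound to a sulfur gives a 2.7-fold higher number from compound 2 to compound 3 (0.43 log units; beyond the scatter) and leaves a modest loss. The aryl group counts for more here, as 2-hydroxyphenyl in place of 4-methoxyphenyl gives a 19-fold lower number from compound 1 to compound 3 (1.28 log units; beyond the scatter) in a large gain. No measurement at hand gives a reason for either step. Open, going by these compounds, is how a butyl chain or an amine would compare at the sulfur-bound carbon. Also open, on these data alone, is whether the aryl step follows from the hydroxy group, the methoxy group or their placement.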